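The source may hold more compounds than are shown below. What is called first, only, known or untested is meant among the compounds shown, and "the series" means these compounds.

Compound 2 `O=C(CCc1ccc(C2CCCCC2)cc1)N1CCCC1` is the stronger of the two measured compounds: in an assay on HEK293 cells for inhibition of N-acylethanolamine-hydrolyzing acid amidase (Rattus norvegicus), read by LC-MS, with a stated time of 30 min (on this read-out lower numbers stand for stronger inhibition and higher numbers for weaker inhibition), compound 2 gives 500 nM, while compound 1 `Cc1ccc(-c2ccc(CCC(=O)N3CCCC3)cc2)cc1` gives 33200 nM. Among the compounds with values here, the single change between them produced a 66-fold lower number from compound 1 to compound 2 (1.82 log units; beyond the scatter). Compound 3 `O=C(CCc1ccc(Oc2ccccc2)cc1)N1CCCC1` differs from compound 2 in one place as well: phenoxy in place of cyclohexyl on an aromatic carbon. Within the data shown here, since the only measured step moved far when a flat aromatic group was swapped for a saturated ring, a move back toward an aromatic group is expected to weaken inhibition, giving a 6.0-fold higher number from compound 2 to compound 3 (0.78 log units; beyond the scatter). Compound 3 is therefore estimated at 3000 nM, within a range from 600 nM to 15000 nM.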

Compound 3, half-maximal inhibitory concentration: > 100000 nM
Compound 3: no number, only a limit (the forecaster's own chance of this, stated with the estimate: 10%); at least 33-fold (1.52 log units) between middle value and limit.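

Compound 3 gives only a limit of the assay, not a number: the limit of > 100000 nM in this assay, at which 1 of the 3 values shown sits. At this position, phenoxy in place of cyclohexyl gives an at least 200-fold higher number from compound 2 to compound 3 (2.30 log units; beyond the scatter), and phenoxy in place of 4-methylphenyl gives an at least 3.0-fold higher number from compound 1 to compound 3 (0.47 log units; beyond the scatter). Among these three groups, then, the non-aromatic cyclohexyl ring stands alone on the strong side, and an aromatic ring in the group goes with weak inhibition both with and without the oxygen link.

The compounds shown cannot separate the contribution of the oxygen from that of the aromatic ring in phenoxy. Going by these compounds, whether cyclohexyloxy, cyclopentyl or an open hexyl chain would keep the strength of compound 2 remains open.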